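A Repeated Aryl Swap Across Two Related Cores

The source may report more compounds than this note shows. Statements on the series, on what has been measured and on what is new or still open speak of the compounds shown alone.

Compound 1 `CC(O)(CSc1ccc(F)cc1)C(=O)Nc1ccc(S(F)(F)(F)(F)F)cc1` and compound 2 `CC(O)(CSc1cccc(C(F)(F)F)c1)C(=O)Nc1ccc(S(F)(F)(F)(F)F)cc1` share one core, while compound 3 `CC(O)(CS(=O)(=O)c1ccc(F)cc1)C(=O)Nc1cccc(S(F)(F)(F)(F)F)c1` and compound 4 `CC(O)(CS(=O)(=O)c1cccc(C(F)(F)F)c1)C(=O)Nc1cccc(S(F)(F)(F)(F)F)c1` share another; the difference between the two cores is not broken down here. In a functional assay on CWR22R cells (Homo sapiens) for antiproliferative activity, read by propidium iodide staining, with a stated time of 96 h (on this read-out lower numbers stand for stronger inhibition and higher numbers for weaker inhibition), compound 1 gives 13500 nM, and compound 2 gives 23400 nM. The step between them, a 1.7-fold higher number from compound 1 to compound 2 (0.24 log units; within the scatter), arises from a single change: 3-(trifluoromethyl)phenyl in place of 4-fluorophenyl on a sulfur. In this assay compound 3 gives 38900 nM. The unmeasured compound 4 differs from compound 3 by 3-(trifluoromethyl)phenyl in place of 4-fluorophenyl on a sulfonyl sulfur. Within the data shown here, this is the same kind of change as the one seen from compound 1 to compound 2, though the surroundings are not identical: in the measured pair the group sits on a sulfur whose other neighbours are a saturated chain carbon, whereas in the new pair it sits on a sulfonyl sulfur whose other neighbours are a saturated chain carbon. Among the measured compounds shown here, for compound 4 the expected step in this assay is a 1.6-fold higher number from compound 3 to compound 4 (0.20 log units; within the scatter), set beside the earlier step because a 1.7-fold higher number from compound 1 to compound 2 (0.24 log units; within the scatter) is the only measured example of this change and lies within the scatter. The estimate for compound 4 is therefore 62000 nM, with a range from 25000 nM to 150000 nM.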

Compound 4, half-maximal inhibitory concentration: 24600 nM
Compound 4: the middle estimate sits 2.5-fold (0.40 log units) above what was measured; measured number below the stated range.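

In this assay, 3-(trifluoromethyl)phenyl in place of 4-fluorophenyl on a sulfonyl sulfur gives a 1.6-fold lower number from compound 3 to compound 4 (0.20 log units; within the scatter). Each step on its own lies within the scatter, but set side by side the two steps differ by more than the scatter, so in this series the change did not carry over from one core to the other as the same step: the same change on two cores in this assay, a 1.7-fold higher number (0.24 log units; within the scatter) from compound 1 to compound 2 and a 1.6-fold lower number (0.20 log units; within the scatter) from compound 3 to compound 4, 2.7-fold (0.44 log units) apart, beyond the scatter of two such steps. This rests on a single pair for each core, and the difference between the two cores is not broken down, so it does not show which part of the core the disagreement goes with, nor whether it would recur in other pairs.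

The compounds shown leave open how this change would read on a core carrying a sulfinyl group in place of the sulfur or sulfonyl. They also leave open how aryl groups bearing a nitrile, a methoxy group or a carboxylic acid would compare with the two aryl groups seen here.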